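The source may report more compounds than this note shows. Statements on the series, on what has been measured and on what is new or still open speak of the compounds shown alone.

Of the compounds shown here, three sharing one core have been measured in a toxicity assay on KB cells (Homo sapiens) for cytotoxicity, read by fluorescence, with a stated time of 3 days; a lower number here means that less compound is needed, a higher number that more compound is needed for the effect. Compound 1 `CCCCOC(=O)CNC(=O)[C@H](CSc1ccc([N+](=O)[O-])cc1[N+](=O)[O-])NC(=O)CC[C@H](NC(=O)CC(C)C)C(=O)OCCCC` gives 59.6 uM. Compound 3 `CCCCOC(=O)CNC(=O)[C@H](CSc1ccc([N+](=O)[O-])cc1[N+](=O)[O-])NC(=O)CC[C@H](NC(=O)/C=C/c1ccccc1)C(=O)OCCCC` gives 34.4 uM. Compound 2 `CCCCOC(=O)CNC(=O)[C@H](CSc1ccc([N+](=O)[O-])cc1[N+](=O)[O-])NC(=O)CC[C@H](NC(=O)c1ccccc1)C(=O)OCCCC` gives only a limit, > 300 uM, so its true number is not known. Between them, an at least 5.0-fold higher number from compound 1 to compound 2 (0.70 log units; beyond the scatter) and an at least 8.7-fold lower number from compound 2 to compound 3 (0.94 log units; beyond the scatter), while a 1.7-fold lower number from compound 1 to compound 3 (0.24 log units; within the scatter). Compound 2 thus stands at the weak end of the three, sitting at the limit of > 300 uM in this assay, at which 1 of the 3 values shown sits. The new compound 4 `CCCCOC(=O)CNC(=O)[C@H](CSc1ccc([N+](=O)[O-])cc1[N+](=O)[O-])NC(=O)CC[C@H](Nc1ccc([N+](=O)[O-])cc1[N+](=O)[O-])C(=O)OCCCC` differs from compound 2 in one place: 2,4-dinitrophenyl in place of benzoyl on an amine nitrogen. Going by the values given here, none of the measured steps covers this kind of change, since each of them swapped one group on a carbonyl carbon for another, whereas here the carbonyl itself is gone. Still, both steps leading away from compound 2 lowered the number beyond the scatter, and compound 1 and compound 3 show that this core can give a measurable number. For compound 4 the value in this assay is therefore expected near 80 uM, between 20 uM and 300 uM. The expected step is an at least 3.7-fold lower number from compound 2 to compound 4 (0.57 log units; beyond the scatter), with a real chance that only a limit is returned again.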

Compound 4, concentration for half-maximal effect: > 300 uM
Compound 4: a limit, no number; the forecaster's own chance of this, stated with the estimate: 40%; middle value at least 3.7-fold (0.57 log units) from the limit.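

In this assay compound 4 gives > 300 uM, which is a limit and not a number; compound 2 also gives only a limit, so the step between them cannot be read. The new information is that 2,4-dinitrophenyl, which has no carbonyl joining it to the amine nitrogen, does not restore a measurable number, with an at least 8.7-fold higher number from compound 3 to compound 4 (0.94 log units; beyond the scatter) and an at least 5.0-fold higher number from compound 1 to compound 4 (0.70 log units; beyond the scatter). Compound 2, with benzoyl, and compound 4, with 2,4-dinitrophenyl, now share the same limit: the limit of > 300 uM in this assay, at which 2 of the 4 values shown sit.

As far as these compounds go, how far apart compound 2 and compound 4 truly lie remains open. Also open, from the compounds shown here alone, is what a plain phenyl on the amine nitrogen would give, which would separate the loss of the carbonyl from the arrival of the two nitro groups.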